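The compounds below may be only part of what the source reports. "The series", "measured", "known", "first", "only" and "open" are said of these compounds alone.

Among the measured compounds shown here, in a physicochemical assay for lipophilicity, read by spectrophotometry, measured as octanol-water partition, at pH 7.4 (a lower number here means a more polar compound, a higher number a more lipophilic compound), compound 1 (`CCOc1cc(CN2CCC(NC(=O)c3ccc(NC)nc3)CC2)cc(OCC)c1F`) gives 2.66, the lowest of the three numbers so far. Compound 3 (`CCOc1cc(CN2CCC(NC(=O)c3cncc(C)c3)CC2)ccc1C`) gives 3.03 and compound 2 (`CCOc1cc(CN2CCC(NC(=O)c3ccc(N)nc3)CC2)cc(OCc2ccccc2)c1-c1ccc(F)cc1`) gives 3.94, both beyond the scatter from compound 1. Compound 4 (`CCOc1cc(CN2CCC(NC(=O)c3cncc(C)c3)CC2)cc(OCC)c1F`) keeps the core of compound 1 and changes one group on a carbonyl carbon: 5-methylpyridin-3-yl in place of 6-(methylamino)pyridin-3-yl on a carbonyl carbon. For the measured compounds named here, no measured pair isolates this change. Going by the values given here, the only guide is compound 3, which carries the same 5-methylpyridin-3-yl group on a different remainder and gives 3.03. A small rise is therefore expected, probably within the scatter, and the estimated step is a number 0.24 log units higher from compound 1 to compound 4 (within the scatter). For compound 4 the expected value is 2.9, with an estimated range of 2.55 to 3.25.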

Compound 4, distribution coefficient: 2.9
Beside the measured number, compound 4's estimate shows no gap at the digits printed; measured number inside the range.
By their numbers in this assay, from the lowest: compounds 1, 4 and 3 (each within the scatter of the next, the first and the last beyond it); then compound 2.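

In this assay, among the compounds shown here, the first step that isolates 5-methylpyridin-3-yl in place of 6-(methylamino)pyridin-3-yl on a carbonyl carbon reads a number 0.24 log units higher from compound 1 to compound 4 (within the scatter) and so does not separate the two groups on this core. This holds even though the entering group has 0 hydrogen-bond donors and the leaving group has 1. Nothing measured here gives a reason for this result.

From the compounds shown here alone, whether a carboxylic acid or a longer chain on this carbonyl carbon would give a step beyond the scatter remains open. So does whether the same exchange reads alike on the remainder of compound 3.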